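The source may report more compounds than this note shows. Statements on the series, on what has been measured and on what is new or still open speak of the compounds shown alone.

In a functional assay on NCI-H460 cells (Homo sapiens) for antiproliferative activity (a higher number here means a weaker inhibitor, a lower number a stronger inhibitor), compound 1 (`COc1ccc(N=C2NC(=O)/C(=C\c3ccc(N(C)C)cc3)S2)cc1`) gives 2520 nM, compound 2 (`Cc1ccc(N=C2NC(=O)/C(=C\c3ccc(N(C)C)cc3)S2)cc1`) gives 940 nM and compound 3 (`CN(C)c1ccc(/C=C2/SC(=Nc3ccc(O)cc3)NC2=O)cc1`) gives 1320 nM. Compound 3 stands within the scatter of both other compounds: a 1.9-fold lower number from compound 1 to compound 3 (0.28 log units; within the scatter) and a 1.4-fold higher number from compound 2 to compound 3 (0.15 log units; within the scatter). Compound 4 (`CN(C)c1ccc(/C=C2/SC(=Nc3ccccc3Cl)NC2=O)cc1`) differs from compound 3 in one place: 2-chlorophenyl in place of 4-hydroxyphenyl on a double-bonded nitrogen. All three measured steps bear on this change, since each alters the group on the double-bonded nitrogen. The only one beyond the scatter, a 2.7-fold lower number from compound 1 to compound 2 (0.43 log units; beyond the scatter), is modest. Among the compounds with values here, no measured compound carries a 2-chlorophenyl, so the data give no direct precedent and no direction for this exchange. On the sizes seen so far, no change beyond the scatter is expected. The estimate is a 1.0-fold lower number from compound 3 to compound 4 (0.01 log units; within the scatter), and this expected step carries wide uncertainty. For compound 4 the expected value is 1300 nM, with an estimated range from 450 nM to 3800 nM.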

Compound 4, half-maximal inhibitory concentration: 730 nM
Beside the measured number, compound 4's estimate is 1.8-fold (0.25 log units) above it; the measured number falls inside the stated range.
By their numbers in this assay, from the lowest: compounds 4, 2, 3 and 1 (each within the scatter of the next, the first and the last beyond it).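

In this assay, within the data shown here, 2-chlorophenyl on the double-bonded nitrogen is the first group with chlorine and with no hydrogen-bond donor or acceptor in the group, yet it stays level with two of the earlier groups: 4-hydroxyphenyl, with a 1.8-fold lower number from compound 3 to compound 4 (0.26 log units; within the scatter), and 4-methylphenyl, with a 1.3-fold lower number from compound 2 to compound 4 (0.11 log units; within the scatter). Only the exchange for 4-methoxyphenyl passes the scatter, with a 3.5-fold lower number from compound 1 to compound 4 (0.54 log units; beyond the scatter), and that step is modest, so this position has now accepted four different aryl groups within a narrow span of values. No measurement shown here accounts for these values.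

As far as these compounds go, whether the chlorine itself or its place on the ring sets the value of compound 4 remains open. So does whether an unsubstituted phenyl, an aminophenyl or a carboxylic acid on the phenyl would stay within this span.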